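The source may report more compounds than this note shows. Statements on the series, on what has been measured and on what is new or still open speak of the compounds shown alone.

Measured compounds:

Compound 1 `CCCCc1c(F)c(N)c2c(=O)cc(-c3ccc(N)c(F)c3)oc2c1F` gives in a functional assay on HeLa cells (Homo sapiens) for cytotoxicity, read by neutral red uptake, with a stated time of 3 days; a higher number here means a weaker inhibitor, a lower number a stronger inhibitor > 100000 nM, which is a limit of the assay and not a number.
Compound 2 `Nc1ccc(-c2cc(=O)c3c(N)c(F)c(Cl)c(F)c3o2)cc1F` gives in this assay > 100000 nM, again a limit of the assay.
Compound 3 `CCCCCCCCCCCCCCCCCC(=O)OCc1c(F)c(N)c2c(=O)cc(-c3ccc(N)c(F)c3)oc2c1F` gives in this assay > 100000 nM, also a limit of the assay.

Compound 2 therefore stands where every measured member of the series stands: at the limit of > 100000 nM in this assay, at which 3 of the 3 values shown sit. Going by the values given here, the one single-point step that has been measured, a step that the two limits leave unreadable from compound 1 to compound 2, runs between two limits and its size cannot be read. The pair of compound 2 and compound 3 is not a single-point change, and both of their values are limits, so they tell nothing about direction either.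

The step to the unmeasured compound 4 `NCc1c(F)c(N)c2c(=O)cc(-c3ccc(N)c(F)c3)oc2c1F` is aminomethyl in place of chloro on an aromatic carbon. Among the compounds with values here, no measured step bears on this change: the only measured step is unreadable, and no compound with an aminomethyl group has been tested in this assay. There is thus no basis for expecting a step beyond the scatter in either direction, and the most likely outcome is that compound 4 again returns only a limit.

Compound 4 is expected to give 100000 nM, within a range of 40000 nM to 300000 nM. The step this estimate implies is a number no higher from compound 2 to compound 4 (the limit leaves the size open), which is expected to be no change.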

Compound 4, half-maximal inhibitory concentration: 8800 nM
Beside the measured number, compound 4's estimate is 11-fold (1.06 log units) above it; the measured number lies below the stated range.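

In this assay, going by these compounds alone, the aromatic carbon ortho to two fluoro groups is the first place where a change gives a readable difference: with aminomethyl in place of chloro, the result is an at least 11-fold lower number from compound 2 to compound 4 (1.05 log units; beyond the scatter). At the same place, with amino in place of propyl on a saturated chain carbon bound to an aromatic carbon, the result is an at least 11-fold lower number from compound 1 to compound 4 (1.05 log units; beyond the scatter), so both the chloro and the butyl compound lie on the same side of the aminomethyl compound, while the step between those two still cannot be read. Compound 4 is the only compound here with a value that is not a limit of the assay: the limit of > 100000 nM in this assay, at which 3 of the 4 values shown sit.

The step does not show whether the nitrogen or the added carbon of aminomethyl carries it; a methyl, a hydroxymethyl or an amine attached directly to the ring at this place would separate the two. A longer aminoethyl chain or a dimethylaminomethyl group would show how far the change tolerates more length or substitution on the nitrogen.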